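This account rests on a few compounds, and the source may have more. Where it says the series, first, only, none or still open, it means among the compounds named here.

Compound 1 `O=C1OC(c2cccc3ccccc23)CN1C1CCN(Cc2cc3ccccc3[nH]2)CC1`: < 50200 nM
Compound 2 `O=C1OC(c2ccncc2)CN1C1CCN(Cc2cc3ccccc3[nH]2)CC1`: < 50200 nM
Compound 3 `COc1ccc2nccc(C3CN(C4CCN(CC5CCCCC5)CC4)C(=O)O3)c2c1`: 7940 nM

In an in vitro functional assay on RBL cells for antagonist activity at C-C chemokine receptor type 8 (Homo sapiens), read by FLIPR and calcium flux (on this read-out lower numbers stand for stronger inhibition and higher numbers for weaker inhibition), compound 1 gives only a limit, < 50200 nM. Compound 2 likewise gives only a limit, < 50200 nM. For the measured compounds named here, compound 3 gives the only number in this assay, 7940 nM. The two other values shown are limits. The step that the two limits leave unreadable from compound 1 to compound 2 cannot be read because of the limit of < 50200 nM in this assay, at which 2 of the 3 values shown sit. Compound 4 `COc1ccc2nccc(C3CN(C4CCN(S(=O)(=O)c5ccc(Cl)c(Cl)c5)CC4)C(=O)O3)c2c1` differs from compound 3 by (3,4-dichlorophenyl)sulfonyl in place of cyclohexylmethyl on an amine nitrogen in a ring. Going by the values given here, no measured step concerns this change; the single recorded step, from compound 1 to compound 2, is unreadable and sits at a different position. The step expected here, a 1.3-fold higher number from compound 3 to compound 4 (0.10 log units; within the scatter), is therefore taken as small in either direction, with wide uncertainty. The estimate for compound 4 in this assay is 10000 nM, ranging from 2000 nM to 50000 nM.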

Compound 4, half-maximal inhibitory concentration: < 50200 nM
Compound 4: no number, only a limit; the forecaster's own chance of this, stated with the estimate: 30%; the middle value lies beyond the limit too.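

Compound 4 gives only a limit in this assay, so no step from compound 3 to compound 4 can be read: the limit of < 50200 nM in this assay, at which 3 of the 4 values shown sit.

The compounds shown leave open how (3,4-dichlorophenyl)sulfonyl and cyclohexylmethyl compare on the shared core in this assay.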